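The source may hold more compounds than are shown below. What is called first, only, known or untested is meant among the compounds shown, and "the series" means these compounds.

Measured so far in the same assay:
compound 1, `CC(=O)N(C)C(C)C#CCn1ccnc1`: 3 mg/kg
compound 2, `CC(=O)N(C)C(C)C#CCn1ccnc1C`: > 100 mg/kg
compound 3, `O=C1OCCN1CC#CCn1ccnc1`: 3 mg/kg

In a functional assay on the whole organism for agonist activity, with Mus musculus as the target (a lower number here means that less compound is needed, a higher number that more compound is needed for the effect), compound 1 gives 3 mg/kg. Compound 2 reaches only a limit of this assay, > 100 mg/kg. The change methyl in place of hydrogen on an aromatic carbon therefore brings an at least 33-fold higher number from compound 1 to compound 2 (1.52 log units; beyond the scatter), ending at the limit of > 100 mg/kg in this assay, at which 1 of the 3 values shown sits. Compound 3 gives 3 mg/kg in this assay, level with compound 1; how the two cores differ is not broken down here.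

Compound 4, `Cc1cncn1CC#CCN1CCOC1=O`, differs from compound 3 by methyl in place of hydrogen on an aromatic carbon. The place is not the same as in compound 2, where the methyl sits between two ring nitrogen atoms; in compound 4 it sits next to the ring nitrogen, two ring bonds from the ring nitrogen. So this is the same kind of change, not the same. A large loss is still expected, a 20-fold higher number from compound 3 to compound 4 (1.30 log units; beyond the scatter), because the same kind of change gave an at least 33-fold higher number from compound 1 to compound 2 (1.52 log units; beyond the scatter). Compound 4 is thus estimated at 60 mg/kg, between 10 mg/kg and 300 mg/kg.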

Compound 4, dose for half-maximal effect: > 100 mg/kg
Compound 4 ended at the assay's limit; the forecaster's own chance of this, stated with the estimate: 45%; middle value at least 1.6-fold (0.22 log units) from the limit.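

In this assay, methyl in place of hydrogen on an aromatic carbon brings an at least 33-fold higher number from compound 3 to compound 4 (1.52 log units; beyond the scatter), so a large loss seen on one core also appears on the other, even though the methyl sits at a different place on the ring. Compound 4 reaches a limit of the assay, > 100 mg/kg, and this is not a number. The size of the change therefore cannot be compared between the two cores, and the different methyl places mean that an effect of the core cannot be separated from an effect of place: the same change on two cores in this assay, an at least 33-fold higher number (1.52 log units; beyond the scatter) from compound 1 to compound 2 and an at least 33-fold higher number (1.52 log units; beyond the scatter) from compound 3 to compound 4; the limit leaves it open whether they differ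

Going by these compounds, it remains open whether a fluorine atom or an ethyl group in place of that hydrogen would also raise the number. On these data alone, it also remains open how far the number rises in either pair.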